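The source may hold more compounds than are shown below. What is called first, only, known or untested is meant among the compounds shown, and "the series" means these compounds.

In a functional assay on KB cells (Homo sapiens) for inhibition, read by MTT assay, with a stated time of 24 h, tested at 1 ug/mL (on this read-out higher numbers stand for more inhibition of growth at the one concentration tested and lower numbers for less inhibition of growth), compound 1 (`O=C(O)CCCCC(CCSC(=O)c1ccccc1)SC(=O)c1ccccc1`) gives 0.68% and so stands within the scatter of compound 2 (`CC(=O)SCCC(CCCCC(=O)Nc1ccccc1Cl)SC(C)=O`) with 8.21%. Compound 3 (`CC(=O)SCCC(CCCCC(=O)Nc1ccc(Cl)cc1)SC(C)=O`) gives 14.8% on this scale. The gap between compound 1 and compound 3 lies beyond the scatter. Compound 4 (`O=C(CCCCC(CCSC(=O)c1ccccc1)SC(=O)c1ccccc1)Nc1ccc(Cl)cc1`) has (4-chlorophenyl)amino in place of hydroxy on a carbonyl carbon. For the measured compounds named here, no measured step makes this exchange. Going by the values given here, the one measured step is a number 6.6 percentage points higher from compound 2 to compound 3 (within the scatter) and it bears only on the place of the chlorine. Compound 3 carries the same (4-chlorophenyl)amino group on a different thioester pattern, and its 14.8% is the nearest guide. An upward move is therefore expected in this assay, with the estimated step (a number 14.3 percentage points higher from compound 1 to compound 4 (beyond the scatter)). For compound 4 the expected value is (15%), with an estimated range from 4% to (35%).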

Compound 4, percent growth inhibition at one concentration: 11.7%
Compound 4: the middle estimate sits 3.3 percentage points above what was measured; the range from low to high includes it.
By their numbers in this assay, from the lowest: compounds 1, 2, 4 and 3 (each within the scatter of the next, the first and the last beyond it).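

On the carbonyl carbon, (4-chlorophenyl)amino in place of hydroxy now gives a direct reading in this assay (a number 11 percentage points higher from compound 1 to compound 4 (beyond the scatter)). This step is modest but lies beyond the scatter, whereas the earlier step (a number 6.6 percentage points higher from compound 2 to compound 3 (within the scatter)) bore only on the place of the chlorine and stayed within it. No measurement at hand accounts for this change.

From the compounds shown here alone, whether the chlorine is needed for this step remains open, since phenylamino could be compared on the same carbonyl carbon. Also open, going by these compounds, is how a methyl ester or a longer chain would read at this position.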